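This account rests on a few compounds, and the source may have more. Where it says the series, first, only, none or still open, it means among the compounds named here.

Measured so far in an assay on NK92 cells for inhibition of interleukin-2 (Homo sapiens), read by AlphaScreen, with stated times of 30 min and 1 h; a higher number here means a weaker inhibitor, a lower number a stronger inhibitor:
compound 1 `CCOC(CCn1c(Cc2nn(C)c(=O)c3ccccc23)nnc1SCC(=O)Nc1ccc(Cl)cc1Cl)OCC`; compound 1 gives > 30000 nM, a limit of the assay.
compound 2 `Cn1nc(Cc2nnc(SCCCCCCCC(=O)Nc3ccc(Cl)cc3Cl)n2CCC(=O)O)c2ccccc2c1=O`; compound 2 gives 14300 nM.
compound 3 `Cn1c(Cc2nn(CCCO[Si](C)(C)C(C)(C)C)c(=O)c3ccccc23)nnc1SCCCCCCCC(=O)Nc1ccc(Cl)cc1Cl`; compound 3 gives > 30000 nM, again a limit of the assay.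

Compound 3 therefore has no number of its own in this assay; it sits at the limit of > 30000 nM in this assay, at which 2 of the 3 values shown sit, so only an upper bound on its inhibition is known. Among the compounds with values here, compound 2 is the single member of the series with a measured half-maximal inhibitory concentration, and that value is itself weak.

Compound 4 `Cn1c(Cc2nn(CCCO)c(=O)c3ccccc23)nnc1SCCCCCCCC(=O)Nc1ccc(Cl)cc1Cl` differs from compound 3 by a hydrogen atom in place of a group of 7 heavy atoms (6 carbon, 1 silicon; no ring), on an oxygen on a saturated carbon, leaving a free hydroxyl on the chain. Within the data shown here, no measured pair shows this change, so no step size is known for it. Given that compound 3 gave only a limit, the step expected from compound 3 to compound 4 is an at least 1.5-fold lower number from compound 3 to compound 4 (0.17 log units; that floor lies within the scatter), at most a modest gain and possibly none beyond the scatter. Compound 4 is estimated at 20000 nM, between 8000 nM and 60000 nM, with a real chance that the assay again reports only a limit.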

Compound 4, half-maximal inhibitory concentration: > 30000 nM
Compound 4: only a limit was reported (the forecaster's own chance of this, stated with the estimate: 55%); at least 1.5-fold (0.17 log units) between middle value and limit.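

Compound 3 and compound 4 both give only a limit, so no step can be read between them: the limit of > 30000 nM in this assay, at which 3 of the 4 values shown sit. The compounds shown leave open whether a hydrogen atom in place of the group of 7 heavy atoms, leaving a free hydroxyl on the chain, changes inhibition at all.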